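One Ring Trimmed to a Single Chlorine

The compounds below may be only part of what the source reports. "The series", "measured", "known", "first", "only" and "open" are said of these compounds alone.

Compound 1 `CC(C)(C)N1C[C@@H](C(=O)Nc2nccn2Cc2ccc(Cl)cc2)[C@H](c2ccc(F)cc2F)C1` gives > 10000 nM in a functional assay for agonist activity at Melanocyte-stimulating hormone receptor (Homo sapiens), read by cAMP accumulation (on this read-out higher numbers stand for an effect only at larger amounts of compound and lower numbers for an effect already at smaller amounts), which is a limit of the assay and not a number.
Compound 2 `CC(C)(C)N1C[C@@H](C(=O)Nc2nccn2Cc2ccccc2-c2ccccc2)[C@H](c2ccc(F)cc2F)C1` gives 527 nM in this assay.
Compound 3 `Cn1c(NC(=O)[C@@H]2CN(C(C)(C)C)C[C@H]2c2ccc(F)cc2F)nc2ccccc21` gives > 10000 nM in this assay, again a limit rather than a number.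

Among these three, compound 2 is the only one with an actual number; the other two sit at the limit of > 10000 nM in this assay, at which 2 of the 3 values shown sit. Compound 2 is therefore the anchor for the step to compound 4 `CC(C)(C)N1C[C@@H](C(=O)Nc2nccn2Cc2ccccc2Cl)[C@H](c2ccc(F)cc2F)C1`, which differs from it in one place: chloro in place of phenyl on an aromatic carbon.

Among the compounds with values here, only one measured step touches this part of the molecule, the change an at least 18-fold lower number from compound 1 to compound 2 (1.27 log units; beyond the scatter), where a chlorine at one position of the benzyl ring gave way to a second phenyl ring at another. Compound 4 keeps a chlorine but moves it to the position the phenyl occupied in compound 2, so it lies between the two measured cases and neither step describes it exactly. The expectation for this assay is a weakening, with a 5.7-fold higher number from compound 2 to compound 4 (0.76 log units; beyond the scatter), because the loss of the phenyl ring reverses most of the change seen in an at least 18-fold lower number from compound 1 to compound 2 (1.27 log units; beyond the scatter) while the retained ortho substitution may keep some of the gain. Compound 4 is thus estimated at 3000 nM, within a range from 600 nM to 15000 nM.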

Compound 4, half-maximal effective concentration: 1270 nM
For compound 4 the middle estimate is 2.4-fold (0.37 log units) above the measured one; the range from low to high includes it.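

At this place on the ring, the phenyl is not needed for a measurable effect in this assay: swapping it for a single chlorine costs only a modest amount, with a 2.4-fold higher number from compound 2 to compound 4 (0.38 log units; beyond the scatter) and a real number still in hand. Within the data shown here, the position of the chlorine also matters, a point the earlier compounds could not show, since the 2-chlorophenyl and 4-chlorophenyl groups differ only in where that one atom sits, and the change gives an at least 7.8-fold lower number from compound 1 to compound 4 (0.89 log units; beyond the scatter) as the size of the gain. That gain can only be stated as a lower bound because compound 1 rests at a limit of the assay and not at a number: the limit of > 10000 nM in this assay, at which 2 of the 4 values shown sit.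

Still open, on these data alone, is whether the gain belongs to chlorine itself or to any small group at this place, which a methyl, a methoxy or a fluorine there would help to settle. Also open, as far as these compounds go, are how a 3-chlorophenyl group would compare with the 2-chlorophenyl and 4-chlorophenyl groups, and whether a phenyl moved to the far end of the ring, as a 4-phenylphenyl group, would keep the effect of the 2-phenylphenyl group.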